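A few compounds are considered here, and "the series" means these few. Any claim that something is new, unique, unknown or untested is made for them only; others in the source may bear on it.

Measured so far in a functional assay on A549 cells (Homo sapiens) for inhibition, read by MTT assay, with a stated time of 72 h, tested at 10 uM; on this read-out lower numbers stand for less inhibition and higher numbers for more inhibition at the one concentration tested (going by the name of the read-out):
- compound 1, `CCOC(=O)C1=C(Nc2ccccc2)S/C(=C\c2ccccc2)C1=O`, gives 29.6%.
- compound 2, `CCOC(=O)C1=C(Nc2ccccc2)S/C(=C\c2ccc(O)c(O)c2)C1=O`, gives 30.7%.
- compound 3, `CCOC(=O)C1=C(Nc2ccccc2)S/C(=C\c2cccc(C(=O)O)c2)C1=O`, sits at a limit of the assay, < 10%.

Compound 3 thus stands at the bottom of the three: its read-out is not a number but (the limit of < 10% in this assay, at which 1 of the 3 values shown sits). Compound 1 and compound 2 both gave numbers, and the step of a number at least 19.6 percentage points lower from compound 1 to compound 3 (beyond the scatter) as well as the step of a number at least 20.7 percentage points lower from compound 2 to compound 3 (beyond the scatter) ran downward, each at least modest. Among the compounds with values here, the single change in each was the arrival of the carboxy group.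

Compound 4, `CCOC(=O)C1=C(Nc2ccccc2)S/C(=C\c2ccc[nH]2)C1=O`, now takes that group away again: 1H-pyrrol-2-yl in place of 3-carboxyphenyl on a double-bonded chain carbon bound to a double-bonded ring carbon. Of the measured steps, a number at least 19.6 percentage points lower from compound 1 to compound 3 (beyond the scatter) bears most directly, since it shows what the carboxy group alone cost; its removal in compound 4 is expected to undo much of that loss, even though the ring that enters differs from the phenyl of compound 1. The step of a number at least 15 percentage points higher from compound 3 to compound 4 (beyond the scatter) is therefore expected to run upward, beyond the scatter. Compound 4 is estimated to give 25%, with a range from 8% to 42%.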

Compound 4, a percentage reported as inhibition, at one concentration (the size of the read-out at that concentration, not a potency): 23.5%
Estimate against measurement, compound 4: 1.5 percentage points above; measured number inside the range.
By their numbers in this assay, from the lowest: compounds 4, 1 and 2 (each within the scatter of the next). At a limit, below all of these: compound 3.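

In this assay, a five-membered aromatic ring with one hetero atom serves this place on the double-bonded chain carbon as well as the six-membered rings do, since the step of a number 6.1 percentage points lower from compound 1 to compound 4 (within the scatter) and the step of a number 7.2 percentage points lower from compound 2 to compound 4 (within the scatter) both stay within the scatter. The step of a number at least 13.5 percentage points higher from compound 3 to compound 4 (beyond the scatter) adds that the low read-out goes with the 3-carboxyphenyl group in particular, not with any departure from plain phenyl. Compound 3 remains a limit of the assay, not a number: the limit of < 10% in this assay, at which 1 of the 4 values shown sits.

Going by these compounds, whether a phenyl ring carrying an amine or a methyl ester would behave like compound 3 or like compound 4 stays open. Also open, on these data alone, is whether any group at this place can raise the read-out beyond the scatter of the three numbers seen so far.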